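This account rests on a few compounds, and the source may have more. Where it says the series, first, only, none or still open, it means among the compounds named here.

Compound 2 `Nc1ncc(-c2ccc(C(=O)O)cc2)nc1-c1ccc(C(F)(F)F)cc1` gives > 90% in an ADME assay on microsomes from liver (Mus musculus) for metabolic stability, read by LC-MS, using NADPH, with a stated time of 30 min, tested at 0.1 uM, in the presence of a further agent that is not named here (on this read-out lower numbers stand for a less stable compound and higher numbers for a more stable compound), as its read-out, and this is a limit of the assay, not a number. Compound 1 `Nc1ncc(-c2ccc(C(=O)N3CC[C@@H](O)C3)cc2)nc1-c1ccc(C(F)(F)F)cc1` gives > 90% in this assay as well, and this too is a limit. Among the compounds with values here, the only measured step is a step that the two limits leave unreadable from compound 1 to compound 2 and the evidence so far stops at the limit of > 90% in this assay, at which 2 of the 2 values shown sit, for both compounds. Compound 3 `Nc1ncc(-c2ccc(C(=O)N3CCC(O)CC3)cc2)nc1-c1ccc(C(F)(F)F)cc1` differs from compound 2 by 4-hydroxypiperidin-1-yl in place of hydroxy on a carbonyl carbon with 4-hydroxypiperidin-1-yl in place of hydroxy on a carbonyl carbon. Compound 1 has 3-hydroxypyrrolidin-1-yl on that carbonyl carbon and sits with compound 2 at the limit of > 90% in this assay, at which 2 of the 2 values shown sit, so no step beyond the scatter is expected in this assay for this change. The expected step is a step that the limit leaves unreadable from compound 2 to compound 3 and it is estimated to stay within the scatter. For compound 3 the estimated value is 92% with an expected range from 78% to 100% as its ends.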

Compound 3, percent of the compound remaining: > 90%
Compound 3: no number, only a limit; the forecaster's own chance of this, stated with the estimate: 60%; the middle value is on the limit's open side.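

No new step can be read: compound 3 joins compound 1 and compound 2 at a limit of the assay, so its steps to both stay unreadable: the limit of > 90% in this assay, at which 3 of the 3 values shown sit.

The compounds shown leave open which group on the carbonyl carbon, if any, would change the percent remaining in this assay.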